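Trading naphthalen-1-yl for 4-fluorophenyl in compound 1

The source may report more compounds than this note shows. Statements on the series, on what has been measured and on what is new or still open speak of the compounds shown alone.

In a functional assay on HL-60 cells (Homo sapiens) for inhibition, read by CCK-8 assay, with a stated time of 48 h, tested at 20 uM (on this read-out lower numbers stand for less inhibition of growth and higher numbers for more inhibition of growth at the one concentration tested), compound 1 `N#C/C(=C\c1ccccc1OS(=O)(=O)c1ccccc1[N+](=O)[O-])C(=O)Nc1nnc(Cc2cccc3ccccc23)s1` gives 23%. Compound 2 `N#C/C(=C\c1ccccc1OS(=O)(=O)c1ccc(Cl)cc1)C(=O)Nc1nnc(Cc2cccc3ccccc23)s1` gives 15%, and compound 3 `N#C/C(=C\c1ccccc1OS(=O)(=O)c1ccc(F)cc1)C(=O)Nc1nnc(Cc2cccc3ccccc23)s1` gives 12%. Compound 1 therefore stands clear only of compound 3, with a number 11 percentage points lower from compound 1 to compound 3 (beyond the scatter), set against a number 8 percentage points lower from compound 1 to compound 2 (within the scatter). Compound 4 `N#C/C(=C\c1ccccc1OS(=O)(=O)c1ccccc1[N+](=O)[O-])C(=O)Nc1nnc(Cc2ccc(F)cc2)s1` differs from compound 1 in one place: 4-fluorophenyl in place of naphthalen-1-yl on a saturated chain carbon bound to an aromatic carbon, with 4-fluorophenyl in place of naphthalen-1-yl on a saturated chain carbon bound to an aromatic carbon. Within the data shown here, no measured step touches this place. All of them alter the sulfonyl side, the smallest being a number 3 percentage points lower from compound 2 to compound 3 (within the scatter), so they suggest a rough size but no direction. In this assay no step beyond the scatter is expected, and the estimated change is a number 1 percentage points lower from compound 1 to compound 4 (within the scatter). For compound 4 the estimated value is 22%, with an expected range from 8% to 45%.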

Compound 4, percent growth inhibition at one concentration: 35%
Compound 4: the middle estimate sits 13 percentage points below what was measured; measured number inside the range.
By their numbers in this assay, from the lowest: compounds 3, 2 and 1 (each within the scatter of the next, the first and the last beyond it); then compound 4.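

Among these compounds, the earlier compounds changed only the sulfonyl side, so this is the first look at the group on the saturated chain carbon bound to an aromatic carbon. In this assay, 4-fluorophenyl in place of naphthalen-1-yl gives a number 12 percentage points higher from compound 1 to compound 4 (beyond the scatter) and shows that this place can shift growth inhibition even when one aromatic ring replaces two. No measurement shown explains the rise.

This single swap removes a ring and adds fluorine together, leaving their separate contributions unresolved. A plain phenyl or a 4-methoxyphenyl here remains an open comparison.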